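The compounds below may be only part of what the source reports. "The series", "measured", "known", "first", "only" and "open" are said of these compounds alone.

In an ADME assay on the whole organism (plasma, strain Sprague-Dawley) for pharmacokinetics, with Rattus norvegicus as the target, at a dose of 5 mg/kg by the oral route (a lower number here means less compound in the circulation, a higher number more compound in the circulation at the dose given), compound 1 `CN(C)CC[C@H](CSc1ccccc1)Nc1ccc(S(=O)(=O)NC(=O)c2ccc(N3CCN(Cc4ccccc4-c4ccc(Cl)cc4)CC3)cc2)cc1C(F)(F)F` gives 3690 ng.h/mL. In this assay compound 2 `CN(C)CC[C@H](CSc1ccccc1)Nc1ccc(S(=O)(=O)NC(=O)c2ccc(N3CCN(Cc4ccccc4-c4ccc(Cl)cc4)CC3)cc2)cc1S(C)(=O)=O` gives "not determined" (no result reported). In this assay compound 3 `CN(C)CC[C@H](CSc1ccccc1)Nc1ccc(S(=O)(=O)NC(=O)c2ccc(N3CCN(Cc4ccccc4-c4ccc(Cl)cc4)CC3)cc2)cc1` gives "not determined" (no result reported).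

For the measured compounds named here, compound 1 therefore holds the only number in this small set, so it cannot be ranked against the others, and no measured step shows how far a change in this part of the structure moves the read-out. Compound 4 `CN(C)CC[C@H](CSc1ccccc1)Nc1ccc(S(=O)(=O)NC(=O)c2ccc(N3CCN(Cc4ccccc4-c4ccc(Cl)cc4)CC3)cc2)cc1S(=O)(=O)C(F)(F)F` has (trifluoromethyl)sulfonyl in place of trifluoromethyl on an aromatic carbon, a difference from compound 1 of (trifluoromethyl)sulfonyl in place of trifluoromethyl on an aromatic carbon. With only compound 1 at 3690 ng.h/mL as a guide, no change beyond the usual scatter is expected in this assay, and no direction is favoured. The expected step is a 1.1-fold higher number from compound 1 to compound 4 (0.04 log units; within the scatter). Compound 4 is estimated at 4000 ng.h/mL, with an expected range from 1500 ng.h/mL to 11000 ng.h/mL.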

Compound 4, area under the concentration-time curve: 747 ng.h/mL
Compound 4: the middle estimate sits 5.4-fold (0.73 log units) above what was measured, and the stated range ends above it.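

In this assay, for the compounds shown here, this aromatic carbon is not indifferent to what it carries: (trifluoromethyl)sulfonyl in place of trifluoromethyl gives a 4.9-fold lower number from compound 1 to compound 4 (0.69 log units; beyond the scatter), the first readable step at this position. The group here can therefore shift how much compound reaches the circulation at the dose given. Nothing available explains this drop.

Steps involving compound 2 and compound 3 cannot be read, so it stays open whether the sulfonyl link alone accounts for the change. From the compounds shown here alone, how a nitrile or a carboxylic acid on this carbon would compare with trifluoromethyl also remains unknown.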